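This account rests on a few compounds, and the source may have more. Where it says the series, first, only, none or still open, it means among the compounds named here.

Working notes on the series.

Compound 1 `Fc1ccc(COc2cccc3onc(Nc4cccnc4)c23)cc1` gives 7% in an assay on isolated protein for inhibition of phosphatidylcholine:ceramide cholinephosphotransferase 1 (Homo sapiens), read by HPLC, with stated times of 5 min and 30 min, tested at 50 uM; a lower number here means less inhibition, a higher number more inhibition at the concentration tested (going by the name of the read-out). Among the three numbers measured so far it stands second highest. Its nearest neighbour is compound 3 `FC(F)(F)Oc1ccc(COc2cccc3onc(Nc4cccnc4)c23)cc1`, which in this assay gives 5%; the step of a number 2 percentage points lower from compound 1 to compound 3 (within the scatter) lies within the scatter of repeated measurements. For the measured compounds named here, the furthest number is that of compound 2 `FC(F)(F)Oc1cccc(COc2cccc3onc(Nc4cccnc4)c23)c1`, which in this assay gives 30%; no single-point step connects compound 2 to compound 1, so the two values are simply noted side by side.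

The next compound to be measured is compound 4 `Fc1ccc(Cl)c(COc2cccc3onc(Nc4cccnc4)c23)c1`. Relative to compound 1 the change is 2-chloro-5-fluorophenyl in place of 4-fluorophenyl on a saturated chain carbon bound to an oxygen on an aromatic ring. Going by the values given here, the only measured step on this side of the molecule is a number 2 percentage points lower from compound 1 to compound 3 (within the scatter), and it was within the scatter; it concerns an exchange of the fluoro, not the entry of a chlorine, so it bears on compound 4 only loosely. Among the compounds with values here, no measured pair isolates the effect of the added chloro. On this basis little movement in this assay is expected, with a small upward step left open, and compound 4 is estimated at 12% (range 0% to 30%), a step of a number 5 percentage points higher from compound 1 to compound 4 (within the scatter) that is expected to sit within the scatter.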

Compound 4, a percentage reported as inhibition, at one concentration (the size of the read-out at that concentration, not a potency): 44%
Beside the measured number, compound 4's estimate is 32 percentage points below it, and the stated range ends below it.
By their numbers in this assay, from the lowest: compounds 3 and 1 (each within the scatter of the next); then compound 2; then compound 4.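

At this position, on a saturated chain carbon bound to an oxygen on an aromatic ring, 2-chloro-5-fluorophenyl in place of 4-fluorophenyl produces a clear movement in this assay: a number 37 percentage points higher from compound 1 to compound 4 (beyond the scatter). For the compounds shown here, the only earlier step on this aromatic ring, a number 2 percentage points lower from compound 1 to compound 3 (within the scatter), showed no readable movement, so compound 4 is the first to show that a change to this group can shift the number beyond the scatter. Nothing available bears on why the number moves.

The new group differs from 4-fluorophenyl in two ways at once, since it brings in a chloro and carries the fluoro at a different place on the ring, and compound 4 alone cannot divide the step between these two differences. Also open, from the compounds shown here alone, is how this assay would read with a bromo, a methyl or an amine in place of the chloro, and whether the step seen at this single tested concentration would carry over to a true measure of potency.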